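The compounds below may be only part of what the source reports. "The series", "measured", "known", "first", "only" and "open" are said of these compounds alone.

Compound 3 `CCCNC(=O)N1CCC(NS(=O)(=O)c2ccc(NC(=O)c3ccccc3C)c3ccccc23)CC1` gives 77.4 nM in an assay on L1.2 cells for binding affinity to C-C chemokine receptor type 8 (Homo sapiens) (on this read-out higher numbers stand for weaker inhibition and lower numbers for stronger inhibition), the highest number among the three measured; compound 1 `Cc1ccccc1C(=O)Nc1ccc(S(=O)(=O)NC2CCN(C(=O)CN)CC2)c2ccccc12` gives 4.1 nM and compound 2 `CNC(=O)N1CCC(NS(=O)(=O)c2ccc(NC(=O)c3ccccc3C)c3ccccc23)CC1` gives 0.7 nM. Compound 4 `Cc1ccccc1C(=O)Nc1ccc(S(=O)(=O)NC2CCN(C(=O)N3CCCCC3)CC2)c2ccccc12` differs from compound 3 by piperidin-1-yl in place of propylamino on a carbonyl carbon. Bearing on this change are a 19-fold higher number from compound 1 to compound 3 (1.28 log units; beyond the scatter) and a 110-fold higher number from compound 2 to compound 3 (2.04 log units; beyond the scatter), both large, and a 5.9-fold lower number from compound 1 to compound 2 (0.77 log units; beyond the scatter), modest; growth of the terminal group on the carbonyl carbon has so far raised the number, but no cyclic group at this position has been measured. A further step upward or none beyond the scatter in this assay is expected, so compound 4 is estimated at 100 nM (range 15 nM to 600 nM), meaning an expected 1.3-fold higher number from compound 3 to compound 4 (0.11 log units; within the scatter).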

Compound 4, inhibition constant: 4.2 nM
Compound 4: the middle estimate sits 24-fold (1.38 log units) above what was measured; the whole stated range lies above it.
By their numbers in this assay, from the lowest: compound 2; then compounds 1 and 4 (each within the scatter of the next); then compound 3.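

In this assay, growth of the group on the carbonyl carbon does not by itself raise the number: with the piperidin-1-yl ring in place of propylamino there is an 18-fold lower number from compound 3 to compound 4 (1.27 log units; beyond the scatter), so compound 4 goes against the trend suggested by compound 2 and compound 3. The ring still leaves a 6.0-fold higher number from compound 2 to compound 4 (0.78 log units; beyond the scatter), while the comparison with aminomethyl gives a 1.0-fold higher number from compound 1 to compound 4 (0.01 log units; within the scatter). No measurement at hand accounts for these differences.

Still open, on these data alone, is whether the ring itself or the absence of the amide hydrogen matters. Dimethylamino, pyrrolidin-1-yl and morpholin-4-yl on this carbonyl carbon would bear on that question.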